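A few compounds are considered here, and "the series" means these few. Any claim that something is new, unique, unknown or untested is made for them only; others in the source may bear on it.

Measured so far in a functional assay on IMR-32 cells with melanin-concentrating hormone receptor 1 (Homo sapiens) as the target, read by fluorescence; a higher number here means a weaker inhibitor, a lower number a stronger inhibitor:
compound 1, `Nc1ccc2cccc(OCCCNCc3ccc(Cl)c(C(F)(F)F)c3)c2n1`: 220 nM
compound 2, `CC(C)c1ccc(C(=O)NCCCOc2cccc3ccc(N)nc23)cc1`: 140 nM

Going by the values given here, the two numbers in this assay lie within the usual scatter of each other, so compound 2 does not stand apart from compound 1, and no step between them can be read. Compound 3, `Nc1ccc2cccc(OCCCNC(=O)Nc3cccc(Cl)c3)c2n1`, is not yet measured. It differs from compound 2 in one place: (3-chlorophenyl)amino in place of 4-isopropylphenyl on a carbonyl carbon. Among the compounds with values here, nothing among the measured compounds shows what this replacement does here, since compound 1 and compound 2 differ in several places at once. The step from compound 2 to compound 3 in this assay is therefore expected to stay within the scatter, or to move only slightly toward a weaker inhibitor; the expected step is a 1.4-fold higher number from compound 2 to compound 3 (0.15 log units; within the scatter). On that basis compound 3 is estimated at 200 nM in this assay, with a range from 60 nM to 700 nM.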

Compound 3, half-maximal inhibitory concentration: 8 nM
Compound 3: the middle estimate sits 25-fold (1.40 log units) above what was measured; the measured number lies below the stated range.
By their numbers in this assay, from the lowest: compound 3; then compounds 2 and 1 (each within the scatter of the next).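

In this assay, (3-chlorophenyl)amino in place of 4-isopropylphenyl on a carbonyl carbon gives an 18-fold lower number from compound 2 to compound 3 (1.24 log units; beyond the scatter) and so shows that this place responds strongly to the group it carries, which compound 1 and compound 2 alone could not show. Both groups hold one six-membered aromatic ring of carbon only, so the step comes with a set of differences that cannot be divided here: the entering nitrogen with its hydrogen-bond donor, the chlorine, and the loss of the isopropyl group. No measurement at hand accounts for the size of this step.

Still open, as far as these compounds go, is how much of the step belongs to the nitrogen and how much to the chlorine; a plain phenylamino group and a 3-chlorophenyl group set directly on the carbonyl carbon would separate the two. Also open, from the compounds shown here alone, is whether a longer chain in the linker keeps the low number of compound 3.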